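The source may hold more compounds than are shown below. What is called first, only, known or untested is meant among the compounds shown, and "the series" means these compounds.

Notes on the series. Compound 1 `Cn1ncnc1-c1cc(Oc2ccc(NC(=O)Nc3cccc(C(F)(F)F)c3)cc2F)ccn1` gives 11600 nM in a functional assay on NCI-H460 cells (Homo sapiens) for antiproliferative activity, read by MTT assay, with a stated time of 72 h; a lower number here means a stronger inhibitor, a higher number a weaker inhibitor. Going by the values given here, compound 2 `Cn1cnnc1-c1cc(Oc2ccc(NC(=O)Nc3cccc(C(F)(F)F)c3)cc2F)ccn1` gives 1270 nM in this assay; the single step within the measured set, a 9.1-fold lower number from compound 1 to compound 2 (0.96 log units; beyond the scatter), concerns only the triazolyl group on the shared core. Compound 3 `CN(C)CCn1cnnc1-c1cc(Oc2ccc(NC(=O)Nc3ccc(Cl)c(C(F)(F)F)c3)cc2F)ccn1` gives 1150 nM in this assay. Against compound 1 its value lies beyond the scatter; against compound 2 the two values are within the scatter of each other. Among the compounds with values here, compound 3 differs from compound 2 in more than one place, so no single step is drawn between them.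

Compound 4 `CN(C)CCn1cnnc1-c1cc(Oc2ccc(NC(=O)Nc3cccc(C(F)(F)F)c3)cc2F)ccn1` is the next entry. The change from compound 3 reads (hydrogen in place of chloro on an aromatic carbon). Within the data shown here, no measured step bears on this carbon: the step from compound 1 to compound 2 sits on a different part of the molecule, and the pair compound 2 and compound 3 cannot be read for the chloro alone. Among the measured compounds shown here, the expectation therefore has no direct precedent in the set and is held loose. The step from compound 3 to compound 4 is expected to be a 1.7-fold higher number from compound 3 to compound 4 (0.24 log units; within the scatter), a modest rise in the number. For compound 4 the estimate in this assay is 2000 nM, with a range from 800 nM to 5000 nM.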

Compound 4, half-maximal inhibitory concentration: 2150 nM
Estimate against measurement, compound 4: 1.1-fold (0.03 log units) below, and the stated range covers the measured number.
By their numbers in this assay, from the lowest: compounds 3, 2 and 4 (each within the scatter of the next); then compound 1.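

Within this assay, chloro and hydrogen on this aromatic carbon, ortho to a trifluoromethyl group, are not told apart, as a 1.9-fold higher number from compound 3 to compound 4 (0.27 log units; within the scatter) shows, and the (dimethylamino)methyl group on the saturated chain carbon bound to an aromatic nitrogen is not told apart from hydrogen either, as a 1.7-fold higher number from compound 2 to compound 4 (0.23 log units; within the scatter) shows; the pair compound 2 and compound 3 could not separate these two changes, whereas each now has its own step, and neither step lies beyond the scatter. Going by these compounds alone, the one step here that lies beyond the scatter concerns the triazolyl group, a 5.4-fold lower number from compound 1 to compound 4 (0.73 log units; beyond the scatter), so compound 4 joins compound 2 in standing apart from compound 1, and the 4-substituted 4H-1,2,4-triazol-3-yl group carries that separation with either a methyl group or the 2-(dimethylamino)ethyl chain on it. No measurement in hand explains any of these steps.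

The compounds shown leave open whether a bromo or a methoxy group on this aromatic carbon would give a value beyond the scatter of those for chloro and hydrogen. Also open, going by these compounds, is whether a longer chain, or a carboxylic acid at the end of the chain on the triazolyl nitrogen, would move the number beyond the scatter of compound 4.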